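From 4-Methoxyphenyl to 2,6-Difluorophenyl on Compound 3

This account rests on a few compounds, and the source may have more. Where it says the series, first, only, none or still open, it means among the compounds named here.

Of the compounds shown here, three have been measured in a functional assay on BGC-823 cells (Homo sapiens) for inhibition, read by sulforhodamine B assay, with a stated time of 3 days; a lower number here means a stronger inhibitor, a higher number a weaker inhibitor. Compound 1 (`O=C1Nc2ccc(F)cc2/C1=C\C(=O)c1ccc(O)cc1F`) gives 6120 nM, compound 2 (`O=C1Nc2ccc(F)cc2/C1=C\C(=O)c1ccc(C2CCCCC2)cc1`) gives 4450 nM, and compound 3 (`COc1ccc(C(=O)Nc2ccc3c(c2)/C(=C/Nc2cccc(N4CCN(C)CC4)c2)C(=O)N3)cc1`) gives 3170 nM. Compound 3 therefore stands within the scatter of both other compounds. Compound 4 (`CN1CCN(c2cccc(N/C=C3\C(=O)Nc4ccc(NC(=O)c5c(F)cccc5F)cc43)c2)CC1`) has 2,6-difluorophenyl in place of the 4-methoxyphenyl of compound 3 on a carbonyl carbon (2,6-difluorophenyl in place of 4-methoxyphenyl on a carbonyl carbon). Going by the values given here, no measured pair isolates this change, so the expectation in this assay is for no shift beyond the scatter and no firm direction. The estimated step of a 1.1-fold lower number from compound 3 to compound 4 (0.02 log units; within the scatter) is correspondingly small. For compound 4 the expected value is 3000 nM, with an estimated range from 1000 nM to 9000 nM.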

Compound 4, half-maximal inhibitory concentration: 2670 nM
The estimate for compound 4 lay 1.1-fold (0.05 log units) above the measured number, within the range that was stated.
By their numbers in this assay, from the lowest: compounds 4, 3, 2 and 1 (each within the scatter of the next, the first and the last beyond it).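

In this assay, the first pair differing in one place gives a 1.2-fold lower number from compound 3 to compound 4 (0.07 log units; within the scatter), so on this carbonyl carbon, whose other neighbour is an amide-type nitrogen, 2,6-difluorophenyl can stand in place of 4-methoxyphenyl with no shift beyond the scatter. The single hydrogen-bond acceptor of the leaving group is therefore not needed to hold the number in this pair. Nothing measured here bears on why the step is so small.

Going by these compounds, whether an unsubstituted phenyl, a carboxylic acid or a longer chain carrying an amine at this place would move the number beyond the scatter remains open. On these data alone, the separate contributions of the methoxy group and the two fluorine atoms also remain open.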